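The source may hold more compounds than are shown below. What is called first, only, known or untested is meant among the compounds shown, and "the series" means these compounds.

In an ADME assay on the whole organism with Oryza sativa as the target, tested at 1 uM (a lower number here means a stronger effect, a higher number a weaker effect of the compound at the concentration tested), compound 2, `C[C@@H](NC(=O)Nc1ccccc1C(C)(C)C)c1ccccc1`, gives 95%, the second highest of the three numbers recorded so far. Compound 3, `C[C@H](NC(=O)Nc1ccccc1C(C)(C)C)c1ccccc1`, gives 99%, and compound 1, `CC(C)c1cccc(NC(=O)N[C@H](C)c2ccccc2)c1`, gives 61%. Within the data shown here, the only step measured between two compounds that differ in one place runs a number 4 percentage points higher from compound 2 to compound 3 (within the scatter); that it stays within the scatter fits because of the fact that compounds 2 and 3 differ only in the configuration as drawn. Compound 4, `C[C@@H](NC(=O)Nc1ccccc1Cl)c1ccccc1`, has not yet been measured. It differs from compound 2 by chloro in place of tert-butyl on an aromatic carbon. Among the measured compounds shown here, no measured step swaps one group for another at that place, so the configuration step offers little guide to the size of this change. The values of compound 1 and compound 2 show that markedly lower numbers do occur among these compounds, but with a different group at a different place. The estimate for compound 4 is therefore 85%, between 55% and 100%. The step this estimate means, a number 10 percentage points lower from compound 2 to compound 4 (within the scatter), is expected to stay within the scatter, though the range allows a larger fall.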

Compound 4, a percentage reported as activity, at one concentration (the size of the read-out at that concentration, not a potency): 103%
Estimate against measurement, compound 4: 18 percentage points below; measured number above the stated range.
By their numbers in this assay, from the lowest: compound 1; then compounds 2, 3 and 4 (each within the scatter of the next).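

Swapping tert-butyl for chloro on this aromatic carbon gives, in this assay, a number 8 percentage points higher from compound 2 to compound 4 (within the scatter), the first measured exchange of one group for another at this place. A group of 4 heavy atoms and a group of 1 heavy atom can therefore occupy this place without moving the read-out beyond the usual scatter, so this one change offers no sign that the read-out depends on which of the two groups is present. Nothing recorded for these compounds gives a reason for this result.

On these data alone, whether an amine, a carboxylic acid or a methoxy group on this same aromatic carbon would move the number beyond the scatter remains open. Also open, as far as these compounds go, is whether chloro would give a similar number in the configuration drawn for compound 3.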